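Moving the chlorine around the phenyl ring on the triazole nitrogen

The source may report more compounds than this note shows. Statements on the series, on what has been measured and on what is new or still open speak of the compounds shown alone.

Measured so far:
- compound 1 `Clc1ccccc1-n1cc(CSc2nc3ccccc3s2)nn1`: 78.1%
- compound 2 `Clc1cccc(-n2cc(CSc3nc4ccccc4s3)nn2)c1`: 39.6%

Both compounds were tested in a functional assay on the whole organism (strain Albino Wistar) for inhibition, with Rattus norvegicus as the target, read by paw edema, with stated times of 1 h and 5 h, at a dose of 10 mg/kg by the oral route; a higher number here means more inhibition at the dose given (going by the name of the read-out), a lower number less inhibition. Compound 1 gives 78.1% there, and compound 2 gives 39.6%. Among the compounds with values here, compound 2 therefore stands lowest of the two numbers; the only step measured, a number 38.5 percentage points lower from compound 1 to compound 2 (beyond the scatter), was a large fall beyond the usual scatter, caused by no more than the chlorine moving from one spot on the phenyl ring to another.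

The next compound, compound 3 `Clc1ccc(-n2cc(CSc3nc4ccccc4s3)nn2)cc1`, repeats this kind of change once more: 4-chlorophenyl in place of 3-chlorophenyl on an aromatic nitrogen. Within the data shown here, the single measured step bears on it only in showing that where the chlorine sits matters a great deal in this assay; it says nothing about which way a third placement will go. The number for compound 3 is therefore hard to call in direction, and a wide range is needed. The expected change is a number 10.4 percentage points higher from compound 2 to compound 3 (beyond the scatter), an estimate that could equally be a rise or a fall. Compound 3 is expected to give about 50% in this assay, somewhere between 25% and 75%.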

Compound 3, a percentage reported as inhibition, in the whole organism at one dose (the size of the read-out at that dose, not a potency): 43.4%
The estimate for compound 3 lay 6.6 percentage points above the measured number, within the range that was stated.
By their numbers in this assay, from the lowest: compounds 2 and 3 (each within the scatter of the next); then compound 1.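

In this assay, the third placement of the chlorine adds a finding that the first pair could not give: a number 3.8 percentage points higher from compound 2 to compound 3 (within the scatter), so the 3-chlorophenyl and 4-chlorophenyl groups cannot be told apart at this position on the triazole nitrogen. The other comparison, a number 34.7 percentage points lower from compound 1 to compound 3 (beyond the scatter), shows that the large gap seen earlier is not tied to the 3-chlorophenyl group alone, and compound 1, with its 2-chlorophenyl group, stands clearly above both other compounds. Nothing available explains why this one placement stands apart.

As far as these compounds go, these three compounds cover only a single chlorine moved around the phenyl ring, so it remains open whether the high number of compound 1 depends on chlorine itself or would also appear with a methyl group, a methoxy group or an amine in the same place on the ring. Also open, from the compounds shown here alone, is how the three compounds would compare at other doses, since each number gives the size of the effect at one dose and is not a potency.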